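Dichlorophenyl in Place of Methoxyphenyl on the Ring Nitrogen

The compounds below may be only part of what the source reports. "The series", "measured", "known", "first", "only" and "open" are said of these compounds alone.

Three compounds sharing one core have been measured in a functional assay with Homo sapiens as the target; on this read-out higher numbers stand for weaker inhibition and lower numbers for stronger inhibition:

compound 1 `Cc1ccc(NC(=O)c2cnn(-c3ccc(F)cc3)c2C)cc1` gives 540 nM
compound 2 `COc1cccc(NC(=O)c2cnn(-c3ccc(F)cc3)c2C)c1` gives 3700 nM
compound 3 `COc1ccc(-n2ncc(C(=O)Nc3ccc(C(F)(F)F)cc3)c2C)cc1` gives 340 nM

Compound 3 has the lowest of the three numbers. Its nearest neighbour is compound 1, whose number is higher but within the usual scatter, so the two cannot be told apart. Compound 2 is furthest, with a number higher than that of compound 3 by more than the scatter.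

The next compound, compound 4 `Cc1c(C(=O)Nc2ccc(C(F)(F)F)cc2)cnn1-c1cccc(Cl)c1Cl`, differs from compound 3 in one place: 2,3-dichlorophenyl in place of 4-methoxyphenyl on an aromatic nitrogen.

Within the data shown here, only one measured step exists, a 6.9-fold higher number from compound 1 to compound 2 (0.84 log units; beyond the scatter), and it changes the group on the amide-type nitrogen, a different place. Among the measured compounds shown here, no measured pair changes the group on the aromatic nitrogen, so nothing here speaks for or against this swap. The expectation is therefore a step of a 1.2-fold higher number from compound 3 to compound 4 (0.07 log units; within the scatter), that is, nothing beyond the scatter, with wide uncertainty. For compound 4 in this assay the estimate is 400 nM, within a range of 90 nM to 1800 nM.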

Compound 4, half-maximal inhibitory concentration: 1600 nM
Compound 4: the middle estimate sits 4.0-fold (0.60 log units) below what was measured; low and high end bracket the measured number.
By their numbers in this assay, from the lowest: compounds 3 and 1 (each within the scatter of the next); then compound 4; then compound 2.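

Among these compounds, this is the first measured change on the aromatic nitrogen, and in this assay the swap gives a 4.7-fold higher number from compound 3 to compound 4 (0.67 log units; beyond the scatter), so the group at this position can weaken inhibition even while the rest of the molecule stays the same. Both groups are built on a six-membered aromatic ring of carbon only, but the entering group carries two chlorine atoms and no hydrogen-bond acceptor, whereas the leaving group carries a methoxy group. No measurement at hand explains the rise in the number.

This one swap removes the methoxy group and adds both chlorines at once, so it remains open which of these changes accounts for the step. Going by these compounds, it is also open how the number would respond to an unsubstituted phenyl, or to a phenyl ring bearing an amine or a carboxylic acid.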